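The source may hold more compounds than are shown below. What is called first, only, known or untested is meant among the compounds shown, and "the series" means these compounds.

Compound 1 `CC1(c2ccccc2)CC(=O)N(CC(=O)N2CCN(c3cccc(C(F)(F)F)c3)CC2)C1=O` and compound 2 `Cc1cccc(N2CCN(C(=O)CN3C(=O)CC(C)(c4ccccc4)C3=O)CC2)c1` share one core and differ only in a single group on the aromatic ring that hangs from the ring nitrogen. In a functional assay on the whole organism (strain CD-1) with Mus musculus as the target, in the maximal electroshock model, with a stated time of 0.5 h (on this read-out higher numbers stand for an effect only at larger amounts of compound and lower numbers for an effect already at smaller amounts), compound 1 gives 300 mg/kg. In this assay compound 2 gives 100 mg/kg. Going by the values given here, the step of a 3.0-fold lower number from compound 1 to compound 2 (0.48 log units; beyond the scatter) is therefore the one measured change in this set, and it places compound 2 as the lower of the two numbers, with compound 1 its only neighbour.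

Compound 3 `COc1ccccc1N1CCN(C(=O)CN2C(=O)CC(C)(c3ccccc3)C2=O)CC1` follows from compound 2 by 2-methoxyphenyl in place of 3-methylphenyl on an amine nitrogen in a ring. Among the compounds with values here, the one measured step bears only loosely on this: it swapped one group for another on the same aromatic ring, and moved the number modestly, so the ring tolerates such changes, but nothing measured here speaks to a methoxy group. With so little to lean on, the expected step of no change at the digits printed from compound 2 to compound 3 (within the scatter) is none beyond the scatter. Compound 3 is therefore estimated at 100 mg/kg in this assay, with a range from 50 mg/kg to 300 mg/kg.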

Compound 3, minimum effective dose: 100 mg/kg
Estimate against measurement, compound 3: no gap at the digits printed, within the range that was stated.
By their numbers in this assay, from the lowest: compounds 2 and 3 (each within the scatter of the next); then compound 1.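

In this assay, putting 2-methoxyphenyl on the amine nitrogen in the ring in place of 3-methylphenyl gives no change at the digits printed from compound 2 to compound 3 (within the scatter). At this position, then, the read-out does not separate the two groups, although they carry their substituents at different places on the aromatic ring and only 2-methoxyphenyl has a hydrogen-bond acceptor. Replacing the 3-(trifluoromethyl)phenyl group with 2-methoxyphenyl gives a 3.0-fold lower number from compound 1 to compound 3 (0.48 log units; beyond the scatter), so a second group now matches the step already seen with 3-methylphenyl, and compound 1 alone stands apart among the three; no measurement at hand explains this result.

Methoxy appears here only as 2-methoxyphenyl and methyl only as 3-methylphenyl, so the compounds shown cannot separate the kind of group from its place on the aromatic ring. As far as these compounds go, it also remains open whether a ring bearing a chlorine atom or a hydroxyl group, or a plain phenyl ring, would give a number like those of compound 2 and compound 3 or one like that of compound 1.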